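The compounds below may be only part of what the source reports. "The series", "measured", "known", "first", "only" and "open" are said of these compounds alone.

Measured compounds:
- compound 1 `CC(C)c1cnc(C(=O)/C=C/c2ccccc2O)cn1`: 78000 nM
- compound 2 `CC(C)Cc1cnc(C(=O)/C=C/c2ccccc2O)cn1`: 63000 nM
- compound 3 `CC(C)Cc1cnc(C(=O)/C=C/c2ccc(O)cc2)cn1`: 232000 nM

In a functional assay on the whole organism for inhibition, with Chlorella vulgaris as the target, read by spectrophotometry, with a stated time of 4 h (on this read-out lower numbers stand for stronger inhibition and higher numbers for weaker inhibition), compound 2 gives 63000 nM and compound 1 gives 78000 nM. The change between them is isopropyl in place of isobutyl on an aromatic carbon and the step it made is a 1.2-fold higher number from compound 2 to compound 1 (0.09 log units; within the scatter). Compound 3, with 232000 nM, differs from compound 2 by 4-hydroxyphenyl in place of 2-hydroxyphenyl on a double-bonded chain carbon bound to a double-bonded chain carbon; that step is a 3.7-fold higher number from compound 2 to compound 3 (0.57 log units; beyond the scatter), and compound 3 stands with the highest number of the three, beyond the scatter from both others.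

Compound 4 `CC(C)c1cnc(C(=O)/C=C/c2ccc(O)cc2)cn1` is not yet measured in this assay. It differs from compound 3 by isopropyl in place of isobutyl on an aromatic carbon, the same change as from compound 2 to compound 1, made on the same place by the same description. The cores of the two pairs differ by 4-hydroxyphenyl in place of 2-hydroxyphenyl on a double-bonded chain carbon bound to a double-bonded chain carbon. Since this change is seen only once so far, the expectation rests on compound 2 and compound 1 and their step of a 1.2-fold higher number from compound 2 to compound 1 (0.09 log units; within the scatter), which was within the scatter. A step of similar size, a 1.2-fold higher number from compound 3 to compound 4 (0.08 log units; within the scatter), is expected from compound 3 to compound 4. Compound 4 is therefore estimated at 280000 nM, with a range from 120000 nM to 650000 nM.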

Compound 4, half-maximal inhibitory concentration: 279000 nM
The estimate for compound 4 lay 1.0-fold (0.00 log units) above the measured number; low and high end bracket the measured number.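

In this assay, isopropyl in place of isobutyl gives a 1.2-fold higher number from compound 3 to compound 4 (0.08 log units; within the scatter), and this step can be set beside the one on the core of compound 2: the same change on two cores in this assay, a 1.2-fold higher number (0.09 log units; within the scatter) from compound 2 to compound 1 and a 1.2-fold higher number (0.08 log units; within the scatter) from compound 3 to compound 4, 1.0-fold (0.01 log units) apart, within the scatter of two such steps. The change therefore carries across these two cores, which differ by 2-hydroxyphenyl and 4-hydroxyphenyl, and on both it leaves the number within the scatter. Among these compounds, this rests on only two pairs and does not show that the two alkyl groups would be interchangeable on a core with any other difference, nor does it give a reason for the small step.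

Still open, from the compounds shown here alone, is whether a longer chain such as hexyl, or an amine or a carboxylic acid, on the same aromatic carbon would move the number beyond the scatter. Also open, going by these compounds, is whether a methoxy group in place of the hydroxyl on the phenyl ring would change the number, and whether the isopropyl and isobutyl pairs would then still agree.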